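Replacing bromine with a thiophene ring on a bicyclic amine

The compounds below may be only part of what the source reports. "The series", "measured", "known", "first", "only" and "open" are said of these compounds alone.

Measured compounds:
compound 1 `CCCCc1csc(CN[C@@H]2C[C@H]3C[C@@H]([C@H]2C)C3(C)C)c1` gives 12500 nM
compound 2 `Cc1ccsc1CN[C@@H]1C[C@H]2C[C@@H]([C@H]1C)C2(C)C` gives 10000 nM
compound 3 `C[C@H]1[C@H](NCc2cc(Br)cs2)C[C@H]2C[C@@H]1C2(C)C` gives 6250 nM

These values come from an ADME assay on MDCK cells (Canis lupus familiaris) for cytotoxicity, read by microscopy, with a stated time of 48 h; a lower number here means that less compound is tolerated, a higher number that more compound is tolerated. Compound 3 stands at the low end of the three numbers, yet the steps of a 2.0-fold lower number from compound 1 to compound 3 (0.30 log units; within the scatter) and a 1.6-fold lower number from compound 2 to compound 3 (0.20 log units; within the scatter) both lie within the scatter, so the three compounds cannot be told apart. Compound 4 `C[C@H]1[C@H](NCc2cc(-c3ccsc3)cs2)C[C@H]2C[C@@H]1C2(C)C` is the next compound. Its change from compound 3: thiophen-3-yl in place of bromo on an aromatic carbon. Both measured steps touched the same aromatic carbon, and neither moved the number beyond the scatter, so no step beyond the scatter is expected in this assay; the estimated step of no change at the digits printed from compound 3 to compound 4 (within the scatter) is small. Compound 4 is expected to give 6250 nM, within 2500 nM to 15000 nM.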

Compound 4, minimum cytotoxic concentration: 25000 nM
Beside the measured number, compound 4's estimate is 4.0-fold (0.60 log units) below it; the measured number lies above the stated range.
By their numbers in this assay, from the lowest: compounds 3, 2, 1 and 4 (each within the scatter of the next, the first and the last beyond it).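

In this assay, within the data shown here, thiophen-3-yl in place of bromo on this aromatic carbon gives a 4.0-fold higher number from compound 3 to compound 4 (0.60 log units; beyond the scatter) and is the first step at this position to pass beyond the scatter, so the position does respond to what it carries. Thiophen-3-yl in place of butyl gives a 2.0-fold higher number from compound 1 to compound 4 (0.30 log units; within the scatter) and so leaves those two compounds indistinguishable. No measurement bears on why the bromo and thiophen-3-yl compounds differ. As far as these compounds go, it remains open whether this step is particular to thiophen-3-yl or would also be seen with a phenyl ring or an amine on this carbon.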